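Swapping the acetyl methyl of compound 3 for 1-methylethenyl

The source may report more compounds than this note shows. Statements on the series, on what has been measured and on what is new or still open speak of the compounds shown alone.

Three amides sharing one core have been tested in a functional assay on KYSE-450 cells (Homo sapiens) for inhibition, read by MTT assay, with a stated time of 48 h; a higher number here means a weaker inhibitor, a lower number a stronger inhibitor. Compound 1 `COc1ccc(CN(C(=O)CCl)c2cc(OC)c(OC)c(OC)c2)cc1O` gives 210 nM, compound 2 `COc1ccc(CN(C(=O)CCCl)c2cc(OC)c(OC)c(OC)c2)cc1O` gives 110 nM, and compound 3 `COc1ccc(CN(C(C)=O)c2cc(OC)c(OC)c(OC)c2)cc1O` gives 160 nM. Compound 3 stands close to both of its neighbours: a 1.3-fold lower number from compound 1 to compound 3 (0.12 log units; within the scatter) and a 1.5-fold higher number from compound 2 to compound 3 (0.16 log units; within the scatter), so the three numbers cannot be told apart. Compound 4 `C=C(C)C(=O)N(Cc1ccc(OC)c(O)c1)c1cc(OC)c(OC)c(OC)c1` differs from compound 3 by 1-methylethenyl in place of methyl on a carbonyl carbon. Every change so far made on the saturated chain carbon bound to this carbonyl carbon has left this assay unmoved, including a 1.9-fold lower number from compound 1 to compound 2 (0.28 log units; within the scatter). On that basis the step to compound 4 is expected to stay within the scatter, a 1.1-fold lower number from compound 3 to compound 4 (0.03 log units; within the scatter). Compound 4 is therefore estimated at 150 nM, with a range from 70 nM to 350 nM.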

Compound 4, half-maximal inhibitory concentration: 200 nM
The estimate for compound 4 lay 1.3-fold (0.12 log units) below the measured number; the measured number falls inside the stated range.
By their numbers in this assay, from the lowest: compounds 2, 3, 4 and 1 (each within the scatter of the next).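

Compound 4 is the only one shown with a double bond outside aromatic rings on this carbonyl carbon, so tolerance in this assay now extends beyond saturated groups at this position. All three of its steps stay within the scatter (a 1.3-fold higher number from compound 3 to compound 4 (0.10 log units; within the scatter)) (a 1.8-fold higher number from compound 2 to compound 4 (0.26 log units; within the scatter)) (a 1.1-fold lower number from compound 1 to compound 4 (0.02 log units; within the scatter)), so 1-methylethenyl cannot be told apart from methyl, 2-chloroethyl or chloromethyl here. No measurement is available to explain this result. The compounds shown leave open how an amine, a carboxylic acid or a longer chain on this carbonyl carbon would read.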